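Piperazin-1-yl in place of trifluoromethyl on compound 2

The source may report more compounds than this note shows. Statements on the series, on what has been measured and on what is new or still open speak of the compounds shown alone.

Measured in an ADME assay on MCF7-DOX cells (Homo sapiens) for cytotoxicity, read by MTT assay, with a stated time of 48 h; on this read-out higher numbers stand for weaker inhibition and lower numbers for stronger inhibition
Compound 1 `COc1cccc(/C=C/C(=O)c2c(OC)cc(OC)c(CC=C(C)C)c2O)c1` gives 49200 nM
Compound 2 `COc1cc(OC)c(C(=O)/C=C/c2ccc(C(F)(F)F)cc2)c(O)c1CC=C(C)C` gives 73700 nM
Compound 3 `COc1cc(OC)c(C(=O)/C=C/c2cccc(C(F)(F)F)c2)c(O)c1CC=C(C)C` gives 66600 nM

Compound 2 stands at 73700 nM and lies within the scatter of compound 1 and compound 3. Compound 4 `COc1cc(OC)c(C(=O)/C=C/c2ccc(N3CCNCC3)cc2)c(O)c1CC=C(C)C` carries piperazin-1-yl in place of trifluoromethyl on an aromatic carbon. Two measured steps changed the group on that ring: a 1.5-fold higher number from compound 1 to compound 2 (0.18 log units; within the scatter) and a 1.1-fold lower number from compound 2 to compound 3 (0.04 log units; within the scatter) both stayed within the scatter. Neither brings in a ring-bearing group of this kind, so the data offer only a loose guide. In this assay the expected step is a 1.8-fold lower number from compound 2 to compound 4 (0.27 log units; within the scatter) and no firm change beyond the scatter is expected. Compound 4 is expected at 40000 nM (estimated range 15000 nM to 90000 nM).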

Compound 4, half-maximal inhibitory concentration: 57800 nM
Estimate against measurement, compound 4: 1.4-fold (0.16 log units) below; the range from low to high includes it.
By their numbers in this assay, from the lowest: compounds 1, 4, 3 and 2 (each within the scatter of the next).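

In this assay, piperazin-1-yl in place of trifluoromethyl on this aromatic carbon brings a 1.3-fold lower number from compound 2 to compound 4 (0.11 log units; within the scatter). The earlier steps shown here changed only small groups on this ring, whereas this one shows that a larger group with a non-aromatic ring and a hydrogen-bond donor also produces no firm change at this position. Nothing measured here accounts for that result.

The compounds shown leave open whether a carboxylic acid or 4-methylpiperazin-1-yl at this place would move the number beyond the scatter.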